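The compounds below may be only part of what the source reports. "The series", "measured", "known", "first", "only" and "open" are said of these compounds alone.

Three analogues built on a shared core have been measured so far. Compound 1 `COc1cccc2c(=O)cc(/C=C/[S+](C)[O-])oc12` gives 9000 nM in a functional assay on DLD-1 cells (Homo sapiens) for cytotoxicity, with a stated time of 48 h; a higher number here means a weaker inhibitor, a lower number a stronger inhibitor. Compound 2 `Cc1c(/C=C/[S+](C)[O-])oc2ccccc2c1=O` gives 7200 nM in this assay. Compound 3 `C[S+]([O-])/C=C/c1cc(=O)c2cc(F)ccc2o1` gives 7000 nM in this assay. Compound 3 has the lowest number of the three, but its gap to compound 2 and its gap to compound 1 both lie within the usual scatter of this kind of measurement, so the three compounds cannot be told apart on these numbers.

The next compound, compound 4 `C[S+]([O-])/C=C/c1cc(=O)c2cc(Br)ccc2o1`, has not yet been measured. It differs from compound 3 in one place: bromo in place of fluoro on an aromatic carbon. Among the compounds with values here, no measured pair in the set shows what a change of this kind does, so the size of the step cannot be read from any earlier step; it can only be expected.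

Because compound 3 gives 7000 nM and the other two values sit close to it in a narrow band, the account expects compound 4 to stay near that band, with at most a small shift toward a lower number. The estimated step from compound 3 to compound 4 is a 1.4-fold lower number from compound 3 to compound 4 (0.15 log units; within the scatter). Compound 4 is therefore estimated at 5000 nM, with a range from 2500 nM to 14000 nM.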

Compound 4, half-maximal inhibitory concentration: 4500 nM
For compound 4 the middle estimate is 1.1-fold (0.05 log units) above the measured one, and the stated range covers the measured number.
By their numbers in this assay, from the lowest: compounds 4, 3, 2 and 1 (each within the scatter of the next).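

In this assay the set now holds its first readable step at this aromatic carbon, on a six-membered aromatic ring of carbon only that is part of a fused system of two rings: bromo in place of fluoro gives a 1.6-fold lower number from compound 3 to compound 4 (0.19 log units; within the scatter) and stays within the usual scatter. This shows that, at this one position, exchanging one single-atom group for the other, neither with any hydrogen-bond donors or acceptors, does not separate the two compounds in their cytotoxicity read-out. No measurement shown here offers an explanation for this result.

From the compounds shown here alone, what remains open is whether this position tolerates groups of a different kind as readily, such as an amine, a carboxylic acid or a longer alkyl chain, since both groups compared here are single atoms. Going by these compounds, it also remains open whether bromo would give a similarly small step on another aromatic carbon of the shared core, or whether a larger step could be found anywhere on that core.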